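The source may report more compounds than this note shows. Statements on the series, on what has been measured and on what is new or still open speak of the compounds shown alone.

Measured compounds in a functional assay on HT-29 cells (Homo sapiens) for cytotoxicity, read by MTT assay, with a stated time of 72 h; on this read-out higher numbers stand for weaker inhibition of growth and lower numbers for stronger inhibition of growth:

Compound 1 `CSc1ccc(CNc2nc(SC)nc3ncccc23)cc1`: 7030 nM
Compound 2 `COc1ccc(CNc2nc(SC)nc3ccccc23)cc1`: a limit of the assay, > 100000 nM
Compound 3 `CSc1nc(NCCCc2ccccc2)c2ccccc2n1`: 89600 nM

Among the two numbers in this assay compound 1 stands lowest. The nearest number belongs to compound 3, which lies beyond the usual scatter of repeated measurements, so compound 1 inhibits growth more strongly than compound 3. For compound 2 the read-out is a limit and not a number: the limit of > 100000 nM in this assay, at which 1 of the 3 values shown sits. Compound 1 is therefore the reference point from which the next step is taken.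

Compound 4 `CSc1nc(NCc2ccccc2)c2cccnc2n1` has not yet been measured in this assay. It differs from compound 1 in one place: hydrogen in place of methylsulfanyl on an aromatic carbon. The core shared with compound 1 is kept, only the substituent para to the large group on the six-membered aromatic ring of carbon only is lost.

Among the measured compounds shown here, no step between measured compounds isolates this kind of change, so the size of the step can only be judged from the spread of the values shown. A modest weakening of growth inhibition is expected, within a few multiples of the value for compound 1 rather than a move toward the limit. The step from compound 1 to compound 4 is estimated at a 2.1-fold higher number from compound 1 to compound 4 (0.33 log units; beyond the scatter). Compound 4 is thus expected to give about 15000 nM in this assay, with a likely range from 4000 nM to 60000 nM.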

Compound 4, concentration for total growth inhibition: > 100000 nM
Compound 4 was reported as a limit; the forecaster's own chance of this, stated with the estimate: 10%; middle value at least 6.6-fold (0.82 log units) from the limit.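

In this assay, hydrogen in place of methylsulfanyl on the aromatic carbon para to a large group is a large change, an at least 14-fold higher number from compound 1 to compound 4 (1.15 log units; beyond the scatter), and it is the first step among these compounds that isolates a single place. It shows that, on the core of compound 1, the growth inhibition seen with compound 1 depends on the methylsulfanyl group at this position, since without that group nothing short of a limit of the assay is recorded. Compound 4 gives a limit and not a number, and it is the second compound to sit there: the limit of > 100000 nM in this assay, at which 2 of the 4 values shown sit.

The compounds shown compare only methylsulfanyl and hydrogen at this position, so they leave open whether a longer chain such as ethylsulfanyl, a chlorine atom or an amine placed there would keep the growth inhibition of compound 1 or lose it. Among the compounds shown here, they also leave open whether the same change would have a step of similar size on another core, and no pair of compounds here can answer that.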